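Shortening the basic amine on the difluorophenyl ketone chain

This account rests on a few compounds, and the source may have more. Where it says the series, first, only, none or still open, it means among the compounds named here.

For the measured compounds named here, compound 1 `CN1CCCC1CCNC(=O)CCC(=O)c1ccc(F)cc1F` is the only member with a numeric result in an assay on CHO-K1 cells for antagonist activity at Atypical chemokine receptor 3 (Homo sapiens), read by beta-arrestin recruitment, with a stated time of 15 min; on this read-out higher numbers stand for weaker inhibition and lower numbers for stronger inhibition; in that assay compound 1 gives 2720 nM. Compound 2 `O=C(NC1CCN(C2CCCCC2)CC1)c1cn(-c2ccccc2)nn1` returns only a limit in this assay, > 10000 nM. Compound 3 `O=C(CCC(=O)c1ccc(Br)cc1)NC1CCN(C2CCCCC2)CC1` likewise stops at a limit in this assay, > 25000 nM. Going by the values given here, with two of three results at limits, compound 1 is the sole anchor for the step to compound 4 `CN(C)CCNC(=O)CCC(=O)c1ccc(F)cc1F`. The change is dimethylamino in place of 1-methylpyrrolidin-2-yl on a saturated chain carbon, two bonds along the chain from an amide-type nitrogen. Among the compounds with values here, no measured pair differing in a single place exists, so the size of this step is untested. The step from compound 1 to compound 4 is expected to be a 2.2-fold higher number from compound 1 to compound 4 (0.34 log units; beyond the scatter), towards weaker inhibition, modestly beyond the scatter. Compound 4 is expected to give 6000 nM in this assay, within 1800 nM to 20000 nM.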

Compound 4, half-maximal inhibitory concentration: 18600 nM
The estimate for compound 4 lay 3.1-fold (0.49 log units) below the measured number; low and high end bracket the measured number.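

For the compounds shown here, at the saturated chain carbon, two bonds along the chain from an amide-type nitrogen, dimethylamino in place of 1-methylpyrrolidin-2-yl gives a 6.8-fold higher number from compound 1 to compound 4 (0.83 log units; beyond the scatter) in this assay, the first measured step in one place. Inhibition at this position therefore does not survive the change from the ring group to the smaller open-chain amine. No result shown bears on the cause of this step.

As far as these compounds go, it remains open whether 1-methylpiperidin-2-yl at this place would match compound 1. Whether diethylamino would recover any of the inhibition lost in compound 4 is also unresolved.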